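Swapping a Hydroxyl Side Chain for Isopropyl

The compounds below may be only part of what the source reports. "The series", "measured", "known", "first", "only" and "open" are said of these compounds alone.

Compound 2 `COC(=O)[C@H](NC(=O)Cn1cc(C2=C(c3c[nH]c4ccccc34)C(=O)N(C)C2=O)c2ccccc21)[C@@H](C)O` gives only a limit in a functional assay on Bel-7402 cells (Homo sapiens) for cytotoxicity, read by MTT assay, with a stated time of 24 h (a higher number here means a weaker inhibitor, a lower number a stronger inhibitor), namely > 100000 nM. Compound 1 `COC(=O)C[C@@H](NC(=O)Cn1cc(C2=C(c3c[nH]c4ccccc34)C(=O)N(C)C2=O)c2ccccc21)C(=O)OC`, which carries (methoxycarbonyl)methyl at the same place, gives 9360 nM in this assay. The measured step of an at least 10-fold higher number from compound 1 to compound 2 (1.02 log units; beyond the scatter) therefore puts compound 2 at the weak end of what has been seen so far, and the limit of > 100000 nM in this assay, at which 1 of the 2 values shown sits, is where it rests. Compound 3 `COC(=O)[C@H](NC(=O)Cn1cc(C2=C(c3c[nH]c4ccccc34)C(=O)N(C)C2=O)c2ccccc21)C(C)C` differs from compound 2 in one place: isopropyl in place of 1-hydroxyethyl on a saturated chain carbon bound to an amide-type nitrogen and a carbonyl carbon. Within the data shown here, no measured step covers this exact exchange; the only step at this position is the large weakening an at least 10-fold higher number from compound 1 to compound 2 (1.02 log units; beyond the scatter), which shows that what sits here can move the number a long way. Compound 3 is expected at 40000 nM, with a range from 8000 nM to 150000 nM. That estimate means an expected change of an at least 2.5-fold lower number from compound 2 to compound 3 (0.39 log units; beyond the scatter), with a real chance that this assay again reports only a limit.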

Compound 3, half-maximal inhibitory concentration: 4010 nM
Compound 3: the middle estimate sits 10-fold (1.00 log units) above what was measured, and the stated range ends above it.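

Exchanging 1-hydroxyethyl for isopropyl gives an at least 24-fold lower number from compound 2 to compound 3 (1.39 log units; beyond the scatter), so this position responds strongly even when both groups have 3 heavy atoms and the main change is a carbon in place of the oxygen of the hydroxyl. Isopropyl also compares well with (methoxycarbonyl)methyl, with a 2.3-fold lower number from compound 1 to compound 3 (0.37 log units; beyond the scatter), which makes it the group with the lowest number in this assay among the three seen at this place. The value for compound 2 is a limit and not a number: the limit of > 100000 nM in this assay, at which 1 of the 3 values shown sits.

The compounds shown do not tell whether the loss of the hydroxyl itself or another difference between the two groups accounts for the step. From the compounds shown here alone, how a longer chain such as isobutyl, an amine or a carboxylic acid would fare at this place also remains open.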